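This account rests on a few compounds, and the source may have more. Where it says the series, first, only, none or still open, it means among the compounds named here.

Measured so far:
compound 1, `COc1ccc(-c2nc(C(F)(F)S(=O)(=O)c3cccc(Cl)c3)nc3ccsc23)cn1`, > 50000 nM
compound 2, `O=S(=O)(Cc1nc(-c2ccoc2)c2sccc2n1)c1cccc(Cl)c1`, > 50000 nM

Compound 1 has the structure `COc1ccc(-c2nc(C(F)(F)S(=O)(=O)c3cccc(Cl)c3)nc3ccsc23)cn1`. In an ADME assay on cells (Homo sapiens) for cytotoxicity, read by resazurin assay, with a stated time of 5 days (a lower number here means that less compound is tolerated, a higher number that more compound is tolerated), compound 1 gives > 50000 nM, which is a limit of the assay and not a number. Compound 2, with the structure `O=S(=O)(Cc1nc(-c2ccoc2)c2sccc2n1)c1cccc(Cl)c1`, also gives > 50000 nM in this assay, again a limit rather than a number. So compound 1 stands at the limit of > 50000 nM in this assay, at which 2 of the 2 values shown sit, and nothing in this small set separates one compound from the other.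

Compound 3, with the structure `COc1ccc(-c2nc(C(F)S(=O)(=O)c3cccc(Cl)c3)nc3ccsc23)cn1`, is not yet measured. It differs from compound 1 in one place: hydrogen in place of fluoro on a saturated chain carbon bound to an aromatic carbon, a fluorine atom and a sulfonyl sulfur. Among the measured compounds shown here, no step between measured compounds is known, so there is no measured basis for a shift in either direction; the expectation is a step no larger than the scatter, and most likely another limit.

Compound 3 is therefore expected to give about 60000 nM in this assay, within a range from 25000 nM to 150000 nM. That estimate implies a step that the limit leaves unreadable from compound 1 to compound 3, which is expected to be within the usual scatter.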

Compound 3, half-maximal cytotoxic concentration: > 50000 nM
Compound 3 ended at the assay's limit; the forecaster's own chance of this, stated with the estimate: 75%; the middle value is on the limit's open side.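

No step from compound 1 to compound 3 can be read in this assay, since each result is a limit and not a number: the limit of > 50000 nM in this assay, at which 3 of the 3 values shown sit.

The compounds shown leave open where each one's true value lies, and which change in structure, if any, would give a readable number.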